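The source may report more compounds than this note shows. Statements on the series, on what has been measured and on what is new or still open speak of the compounds shown alone.

In a functional assay on A549 cells (Homo sapiens) for inhibition, read by sulforhodamine B assay (a higher number here means a weaker inhibitor of growth, a lower number a stronger inhibitor of growth), compound 1 `c1ccc(-c2ccc(-c3ccc(-c4nc5ccccc5[nH]4)cc3)cc2)cc1` gives 41200 nM. Compound 2 `Oc1ccc(-c2ccc(-c3ccc(-c4nc5ccccc5[nH]4)cc3)cc2)cc1` gives 33100 nM, which stands level with compound 1 within the scatter. Compound 3 `COc1ccc(-c2ccc(-c3ccc(-c4nc5ccccc5[nH]4)cc3)cc2)cc1OC` has 3,4-dimethoxyphenyl in place of 4-hydroxyphenyl on an aromatic carbon. Going by the values given here, only one measured step bears on this change, a hydroxy in place of hydrogen on the same ring, and it was small: a 1.2-fold lower number from compound 1 to compound 2 (0.10 log units; within the scatter). On that evidence, no change beyond the scatter is expected in this assay, and the expected step is a 1.2-fold lower number from compound 2 to compound 3 (0.07 log units; within the scatter). Compound 3 is estimated at 28000 nM, with an expected range of 10000 nM to 60000 nM.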

Compound 3, concentration for 50% growth inhibition: 7600 nM
For compound 3 the middle estimate is 3.7-fold (0.57 log units) above the measured one, and the stated range ends above it.
By their numbers in this assay, from the lowest: compound 3; then compounds 2 and 1 (each within the scatter of the next).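

In this assay, this position proves able to move the number beyond the scatter: 3,4-dimethoxyphenyl gives a 4.4-fold lower number from compound 2 to compound 3 (0.64 log units; beyond the scatter) and a 5.4-fold lower number from compound 1 to compound 3 (0.73 log units; beyond the scatter), whereas a single hydroxy on the same ring had left the number within it. Both steps remain modest. Nothing measured here accounts for them.

Whether both methoxy groups are needed remains open, since a ring carrying only one is not among the compounds shown. Also open, as far as these compounds go, is how an amine or a carboxylic acid on this ring would compare.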